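The source may hold more compounds than are shown below. What is called first, only, known or untested is meant among the compounds shown, and "the series" means these compounds.

The series shares one core. Compound 1 `O=C(COc1c(F)cc(C(=O)c2ccc(F)cc2)cc1Cl)NNC(=O)c1ccc(=O)oc1` carries fluoro on the outer aromatic ring, compound 2 `Cc1ccc(C(=O)c2cc(F)c(OCC(=O)NNC(=O)c3ccc(=O)oc3)c(Cl)c2)cc1` carries methyl there, and compound 3 `Cc1ccc(C(=O)c2cc(F)c(OCC(=O)NNC(=O)c3cn(C)cn3)c(Cl)c2)cc1` keeps the methyl but bears a different ring on the carbonyl carbon. In a functional assay on A549 cells (Homo sapiens) for cytotoxicity, read by trypan blue exclusion, with a stated time of 48 h (a lower number here means a stronger inhibitor, a higher number a weaker inhibitor), compound 1 gives 56700 nM, compound 2 gives 19600 nM and compound 3 gives 9600 nM. Compound 2 thus stands second highest of the three numbers: a 2.9-fold lower number from compound 1 to compound 2 (0.46 log units; beyond the scatter), and a 2.0-fold lower number from compound 2 to compound 3 (0.31 log units; beyond the scatter).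

Compound 4 `O=C(COc1c(F)cc(C(=O)c2ccc(Cl)cc2)cc1Cl)NNC(=O)c1ccc(=O)oc1` differs from compound 2 by chloro in place of methyl on an aromatic carbon. Among the compounds with values here, only the step from compound 1 to compound 2 touches this position, and it was modest: a 2.9-fold lower number from compound 1 to compound 2 (0.46 log units; beyond the scatter). Within the data shown here, no measured pair sets chloro against methyl at this place, so the data do not fix a direction for the change. The expected step is a 1.0-fold higher number from compound 2 to compound 4 (0.01 log units; within the scatter), most likely none beyond the scatter. The estimate for compound 4 in this assay is 20000 nM, with a range from 8000 nM to 50000 nM.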

Compound 4, half-maximal inhibitory concentration: 86700 nM
Compound 4: the middle estimate sits 4.3-fold (0.64 log units) below what was measured; measured number above the stated range.
By their numbers in this assay, from the lowest: compound 3; then compound 2; then compounds 1 and 4 (each within the scatter of the next).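

In this assay this position does respond to chloro in place of methyl, with a 4.4-fold higher number from compound 2 to compound 4 (0.65 log units; beyond the scatter), so the methyl of compound 2 is now set against two halogens rather than one. Chloro in place of fluoro gives a 1.5-fold higher number from compound 1 to compound 4 (0.18 log units; within the scatter), so the two halogens are not separated here, and among these compounds methyl alone stands apart at this position. Nothing measured here accounts for the gap between methyl and the halogens.

As far as these compounds go, whether the lower number seen with methyl carries over to an ethyl group, a methoxy group or an amine at this position stays open. Also open, from the compounds shown here alone, is whether chloro in place of methyl gives a similar step when the core carries the ring of compound 3 on the carbonyl carbon.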